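Three Limits and an Expected Fourth

A few compounds are considered here, and "the series" means these few. Any claim that something is new, unique, unknown or untested is made for them only; others in the source may bear on it.

Three compounds share one core and differ only in the ring on the carbonyl carbon. In an ADME assay on Vero cells (Chlorocebus sabaeus) for cytotoxicity, read by MTT assay, with a stated time of 72 h (a higher number here means that more compound is tolerated, a lower number that less compound is tolerated), compound 1 `COC(=O)c1cc(-c2cccc(NC(=O)c3ccc(/C=C/C(=O)c4cccc(F)c4)cc3)c2)on1` gives > 40 ug/mL, which is a limit of the assay rather than a number. Compound 2 `COC(=O)c1cc(-c2cccc(NC(=O)c3ccc(/C=C/C(=O)c4ccccc4OC)cc3)c2)on1` likewise reaches only a limit, > 40 ug/mL, in this assay. Compound 3 `COC(=O)c1cc(-c2cccc(NC(=O)c3ccc(/C=C/C(=O)c4ccc(F)cc4)cc3)c2)on1` also stops at a limit, > 20 ug/mL, in this assay. The three steps among them, a step that the two limits leave unreadable from compound 1 to compound 2, a step that the two limits leave unreadable from compound 1 to compound 3 and a step that the two limits leave unreadable from compound 2 to compound 3, cannot be read, as the limit of > 20 ug/mL in this assay, at which 1 of the 3 values shown sits, and the limit of > 40 ug/mL in this assay, at which 2 of the 3 values shown sit, show. Compound 3 thus stands at a limit, alongside two further limits. Compound 4 `COC(=O)c1cc(-c2cccc(NC(=O)c3ccc(/C=C/C(=O)c4ccccc4C)cc3)c2)on1` differs from compound 3 by 2-methylphenyl in place of 4-fluorophenyl on a carbonyl carbon. For the measured compounds named here, no measured step is readable, so no step beyond the scatter is expected in this assay, namely a step that the limit leaves unreadable from compound 3 to compound 4. Compound 4 is estimated at 45 ug/mL, within 20 ug/mL to 100 ug/mL.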

Compound 4, half-maximal cytotoxic concentration: > 25 ug/mL
Compound 4: no number, only a limit; the forecaster's own chance of this, stated with the estimate: 75%; the middle value is on the limit's open side.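

In this assay compound 4 gives > 25 ug/mL, which is a limit, and its steps to compound 1, compound 2 and compound 3 cannot be read. The compounds shown leave open at what concentration any of the four stops being tolerated, and whether the ring on the carbonyl carbon matters.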